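Changing the Amide-Linked Aryl Group: What to Expect

This account rests on a few compounds, and the source may have more. Where it says the series, first, only, none or still open, it means among the compounds named here.

Compound 1 `CCOc1ccc2nc(NC(=O)COc3ccc4cc(/C=C5/SC(=O)NC5=O)ccc4c3)sc2c1`: 3600 nM
Compound 2 `O=C(COc1ccc2cc(/C=C3/SC(=O)NC3=O)ccc2c1)Nc1cccc(F)n1`: 840 nM
Compound 3 `O=C(COc1ccc2cc(/C=C3/SC(=O)NC3=O)ccc2c1)Nc1ccccc1`: 2100 nM

These three compounds share one core and differ only in the aryl group attached to an amide-type nitrogen. All were tested in an assay on isolated protein for inhibition of histone deacetylase 4 (Homo sapiens), with a stated time of 1 h; on this read-out higher numbers stand for weaker inhibition and lower numbers for stronger inhibition. Among them compound 2 gives the lowest number, 840 nM; compound 3 sits nearest, with a 2.5-fold higher number from compound 2 to compound 3 (0.40 log units; beyond the scatter), and compound 1 sits furthest, giving 3600 nM.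

The unmeasured compound 4 `O=C(COc1ccc2cc(/C=C3/SC(=O)NC3=O)ccc2c1)Nc1ccc([N+](=O)[O-])cc1` departs from compound 2 by a single change: 4-nitrophenyl in place of 6-fluoropyridin-2-yl on an amide-type nitrogen. Among the measured compounds shown here, the one measured step that bears directly on this change is the swap of the same fluoropyridinyl group for plain phenyl, where a 2.5-fold higher number from compound 2 to compound 3 (0.40 log units; beyond the scatter). For the measured compounds named here, compound 4 carries a nitro group on that phenyl ring, and no measured pair shows what adding such a group does, so the phenyl case is the only guide. The expectation for compound 4 in this assay is therefore a modestly higher number, about a 2.4-fold higher number from compound 2 to compound 4 (0.38 log units; beyond the scatter), because a 2.5-fold higher number from compound 2 to compound 3 (0.40 log units; beyond the scatter) went that way. Compound 4 is estimated at 2000 nM, with a range from 700 nM to 6000 nM that reflects the unknown contribution of the nitro group.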

Compound 4, half-maximal inhibitory concentration: 1700 nM
Compound 4: the middle estimate sits 1.2-fold (0.07 log units) above what was measured; low and high end bracket the measured number.
By their numbers in this assay, from the lowest: compound 2; then compounds 4, 3 and 1 (each within the scatter of the next, the first and the last beyond it).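

The new information concerns the nitro group itself: with nitro in place of hydrogen on an aromatic carbon, this assay shows a 1.2-fold lower number from compound 3 to compound 4 (0.09 log units; within the scatter) and so gives no difference between compound 3 and compound 4 that can be told from ordinary assay noise. The 6-fluoropyridin-2-yl group of compound 2 now keeps its lead over a second carbon-only ring, since the change to 4-nitrophenyl gives a 2.0-fold higher number from compound 2 to compound 4 (0.31 log units; beyond the scatter) and the earlier change to plain phenyl went the same way. No independent evidence is available to explain why these numbers fall as they do.

The compounds shown do not separate the roles of the ring nitrogen and the fluorine in compound 2, and a plain pyridin-2-yl group on the same amide-type nitrogen would be the direct test of that. They also leave open whether the phenyl ring would tolerate other groups in place of nitro just as evenly, such as an amine or a carboxylic acid, which could move the number in either direction.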